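The source may hold more compounds than are shown below. What is called first, only, known or untested is meant among the compounds shown, and "the series" means these compounds.

In a functional assay on HeLa cells (Homo sapiens) for antiproliferative activity, read by MTT assay, with a stated time of 72 h (on this read-out higher numbers stand for weaker inhibition and lower numbers for stronger inhibition), compound 1 (`Nc1nc(N)c2cc(CSC(=S)N3CCN(c4ccccc4)CC3)ccc2n1`) gives 2840 nM and compound 2 (`Cc1ccc(N2CCN(C(=S)SCc3ccc4nc(N)nc(N)c4c3)CC2)c(C)c1`) gives 3190 nM. Among the measured compounds shown here, compound 2 therefore stands level with the only other measured compound, within the scatter. Compound 3 (`Nc1nc(N)c2cc(CSC(=S)N3CCN(c4ccc(Cl)c(Cl)c4)CC3)ccc2n1`) departs from compound 2 at one place: 3,4-dichlorophenyl in place of 2,4-dimethylphenyl on an amine nitrogen in a ring. It carries 3,4-dichlorophenyl in place of 2,4-dimethylphenyl on an amine nitrogen in a ring. For the measured compounds named here, one measured step bears on this change, the exchange of phenyl for 2,4-dimethylphenyl at the same nitrogen, a 1.1-fold higher number from compound 1 to compound 2 (0.05 log units; within the scatter), and it lies within the scatter. Going by the values given here, no chlorine-bearing example has been measured, so this single step is thin evidence. On that basis, no step beyond the scatter is expected in this assay, in either direction. The expected step is a 1.3-fold lower number from compound 2 to compound 3 (0.11 log units; within the scatter). For compound 3 the estimated value is 2500 nM, with an expected range from 900 nM to 6000 nM.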

Compound 3, half-maximal inhibitory concentration: 3060 nM
For compound 3 the middle estimate is 1.2-fold (0.09 log units) below the measured one, and the stated range covers the measured number.
By their numbers in this assay, from the lowest: compounds 1, 3 and 2 (each within the scatter of the next).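

In this assay, the change to 3,4-dichlorophenyl gives a 1.0-fold lower number from compound 2 to compound 3 (0.02 log units; within the scatter), and measured against plain phenyl it gives a 1.1-fold higher number from compound 1 to compound 3 (0.03 log units; within the scatter), so both steps lie within the scatter. Chlorine on the aromatic ring at this amine nitrogen is now represented alongside methyl, and phenyl, 2,4-dimethylphenyl and 3,4-dichlorophenyl all stand level, with none of the three compounds going against that pattern. No measurement offered here accounts for this level.

Going by these compounds, whether a methoxy group or a nitrile on the phenyl ring, or a benzyl group or pyridine ring in its place, would move the number beyond the scatter remains open. The compounds also leave open whether this level would hold with a change to the shared core.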